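The source may report more compounds than this note shows. Statements on the series, on what has been measured and on what is new or still open speak of the compounds shown alone.

In a physicochemical assay for solubility, read by spectrophotometry, measured as kinetic solubility, at pH 8, tested at 500 uM (a lower number here means a less soluble compound, a higher number a more soluble compound), three related compounds have been measured so far. Compound 1 `CN1CCCC(NS(=O)(=O)c2ccccc2Nc2cc(-c3ccc4ccn(C)c4c3)c3nccnc3c2)C1` gives 9 ug/mL, compound 2 `Cn1cc(CNS(=O)(=O)c2ccccc2Nc2cc(-c3ccc4ccn(C)c4c3)c3nccnc3c2)cn1` gives 2 ug/mL, and compound 3 `Cn1cc(NC(=O)c2ccncc2Nc2cc(-c3ccc4ccn(C)c4c3)c3nccnc3c2)cn1` gives 2 ug/mL. Compound 3 therefore sits level with compound 2 as the lowest of the three, while compound 1 stands clearly higher.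

Compound 4 `CC(=O)N1CCCC(NC(=O)c2ccncc2Nc2cc(-c3ccc4ccn(C)c4c3)c3nccnc3c2)C1` is not yet measured. It differs from compound 3 in one place, on an amide-type nitrogen: 1-acetylpiperidin-3-yl in place of 1-methyl-1H-pyrazol-4-yl on an amide-type nitrogen.

Going by the values given here, only one measured step bears on this change: a 4.5-fold lower number from compound 1 to compound 2 (0.65 log units; beyond the scatter). There, a 1-methylpiperidin-3-yl group gave way to a (1-methyl-1H-pyrazol-4-yl)methyl group. Read backwards, that step points towards a higher number for compound 4. The match is only partial, however, since the piperidine ring in compound 4 carries an acetyl group and sits on an amide-type nitrogen rather than a sulfonamide nitrogen. Only part of that step is therefore expected to carry over.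

The expected change is a 2.5-fold higher number from compound 3 to compound 4 (0.40 log units; beyond the scatter), a small rise. For compound 4 the estimate is 5 ug/mL, with an expected range from 2 ug/mL to 14 ug/mL.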

Compound 4, solubility: 212 ug/mL
Compound 4: middle estimate off by 42-fold (1.63 log units), on the low side; the whole stated range lies below it.
By their numbers in this assay, from the lowest: compounds 2 and 3 (each within the scatter of the next); then compound 1; then compound 4.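

In this assay, the swap of 1-methyl-1H-pyrazol-4-yl for 1-acetylpiperidin-3-yl on an amide-type nitrogen gives a 110-fold higher number from compound 3 to compound 4 (2.03 log units; beyond the scatter) and so shows that one change at this position can move the read-out a long way. Going by these compounds alone, the only earlier step, a 4.5-fold lower number from compound 1 to compound 2 (0.65 log units; beyond the scatter) on a sulfonamide nitrogen, was modest and gave no sign of a shift this large. Nothing measured here explains the size of the new step.

From the compounds shown here alone, the two groups differ in both the ring and the acetyl at once, so it remains open which of these goes with the rise. A piperidin-3-yl group with a free ring amine, or a methanesulfonyl group in place of the acetyl on the same amide-type nitrogen, would help to separate the two.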